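Trimming Naphthalen-1-yl to Phenyl on the Shared Core

This account rests on a few compounds, and the source may have more. Where it says the series, first, only, none or still open, it means among the compounds named here.

Of the compounds shown here, three built on one shared core have been tested in a functional assay, tested at 50 ug/mL; a lower number here means a weaker effect, a higher number a stronger effect of the compound at the concentration tested. Compound 1 `COc1ccc(C2C(C#N)=C(N)OC(c3c[nH]c4ccccc34)=C2C#N)cc1OC` gives 14.5%. Compound 2 `Cc1ccccc1C1C(C#N)=C(N)OC(c2c[nH]c3ccccc23)=C1C#N` gives 10.4%, and compound 3 `N#CC1=C(N)OC(c2c[nH]c3ccccc23)=C(C#N)C1c1cccc2ccccc12` gives 4.7%. Compound 3 holds the lowest of the three numbers, yet its gap to compound 2, a number 5.7 percentage points lower from compound 2 to compound 3 (within the scatter), and its gap to compound 1, a number 9.8 percentage points lower from compound 1 to compound 3 (within the scatter), both stay within the scatter, so none of the three can be called weaker or stronger than another on these numbers alone.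

Compound 4 `N#CC1=C(N)OC(c2c[nH]c3ccccc23)=C(C#N)C1c1ccccc1` has not yet been measured. It differs from compound 3 in one place: phenyl in place of naphthalen-1-yl on a saturated ring carbon. Every step seen so far swaps the group on this same saturated ring carbon, and each stayed within the scatter: a number 4.1 percentage points lower from compound 1 to compound 2 (within the scatter), a number 9.8 percentage points lower from compound 1 to compound 3 (within the scatter) and a number 5.7 percentage points lower from compound 2 to compound 3 (within the scatter). Three different aromatic groups at that place have thus given much the same low read-out. Keeping one six-membered aromatic ring of carbon only, as phenyl, in place of the two rings of naphthalen-1-yl is expected to behave the same way, so no step beyond the scatter is expected in this assay in either direction. The estimated step is a number 3.3 percentage points higher from compound 3 to compound 4 (within the scatter). Compound 4 is therefore expected to give about 8%, most likely between 0% and 20%.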

Compound 4, a percentage reported as activity, at one concentration (the size of the read-out at that concentration, not a potency): 14.4%
Beside the measured number, compound 4's estimate is 6.4 percentage points below it, and the stated range covers the measured number.
By their numbers in this assay, from the lowest: compounds 3, 2, 4 and 1 (each within the scatter of the next).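

In this assay, phenyl with no substituent now sits alongside the larger groups at this saturated ring carbon: in place of naphthalen-1-yl it gives a step within the scatter (a number 9.7 percentage points higher from compound 3 to compound 4 (within the scatter)), the removal of the methyl from 2-methylphenyl gives another (a number 4 percentage points higher from compound 2 to compound 4 (within the scatter)), and phenyl in place of 3,4-dimethoxyphenyl gives a third (a number 0.1 percentage points lower from compound 1 to compound 4 (within the scatter)). The second aromatic ring, the methyl and the two methoxy groups therefore cannot be told apart from plain phenyl on these numbers, so none of them is shown to matter for this read-out at the concentration tested. No measurement at hand bears on why these four groups read alike.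

Every group shown at this place carries a six-membered aromatic ring of carbon only, so it remains open whether a pyridine ring, a cyclohexyl group or a phenyl ring bearing an amine or a carboxylic acid would give a step beyond the scatter. Going by these compounds, the 1H-indol-3-yl group, the amino group and the two cyano groups stay the same throughout, so what a change at any of those places would do also remains open.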